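A few compounds are considered here, and "the series" means these few. Any claim that something is new, unique, unknown or untested is made for them only; others in the source may bear on it.

For the measured compounds named here, in an assay for inhibition of Tryptophan 2,3-dioxygenase (Homo sapiens), with stated times of 10 min and 60 min, tested at 100 uM (on this read-out lower numbers stand for a weaker effect and higher numbers for a stronger effect at the one concentration tested), compound 3 `FC(F)(F)c1cc(NC[C@H]2CCCCN2)c2cn[nH]c2c1` gives 90%, the second highest of the three numbers measured so far. Compound 1 `Oc1ccc(CNc2cc(C(F)(F)F)cc3[nH]ncc23)cc1` gives 91% and compound 2 `FC(F)(F)c1cc(NC[C@H]2CCCN2)c2cn[nH]c2c1` gives 84%. Compound 4 `FC(F)(F)c1cc(NCc2cccc(Br)c2)c2cn[nH]c2c1` differs from compound 3 in one place: 3-bromophenyl in place of piperidin-2-yl on a saturated chain carbon bound to a nitrogen on an aromatic ring. The step that bears most on this is the one in which 4-hydroxyphenyl stood at the same place, a number 1 percentage points lower from compound 1 to compound 3 (within the scatter); the other two steps, a number 7 percentage points lower from compound 1 to compound 2 (within the scatter) and a number 6 percentage points higher from compound 2 to compound 3 (within the scatter), are likewise within the scatter. All three measured compounds sit close together, so the change to 3-bromophenyl is expected to leave this assay without a step beyond the scatter, a number 2 percentage points lower from compound 3 to compound 4 (within the scatter). Compound 4 is therefore estimated at 88%, with a range of 76% to 97%.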

Compound 4, a percentage reported as inhibition, at one concentration (the size of the read-out at that concentration, not a potency): 84%
For compound 4 the middle estimate is 4 percentage points above the measured one; the range from low to high includes it.
By their numbers in this assay, from the lowest: compounds 2, 4, 3 and 1 (each within the scatter of the next).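

At the saturated chain carbon bound to a nitrogen on an aromatic ring, replacing piperidin-2-yl with 3-bromophenyl removes the hydrogen-bond donor and acceptor counted on piperidin-2-yl, yet the read-out in this assay gives only a number 6 percentage points lower from compound 3 to compound 4 (within the scatter). The comparisons with the other two groups, no change at the digits printed from compound 2 to compound 4 (within the scatter) and a number 7 percentage points lower from compound 1 to compound 4 (within the scatter), also stay within the scatter, so both saturated amine rings and both substituted phenyl rings read alike here. No measurement on hand accounts for this.

From the compounds shown here alone, whether a carboxylic acid at this place gives a step beyond the scatter remains open. With one concentration, potency differences among these compounds also remain unresolved.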